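Acyl and carbamate variation on the piperidine nitrogen: efficacy notes

The source may hold more compounds than are shown below. What is called first, only, known or untested is meant among the compounds shown, and "the series" means these compounds.

Measured in a functional assay on isolated protein for inhibition of Glucose-dependent insulinotropic receptor (Rattus norvegicus), read by HTRF and cAMP accumulation; a lower number here means a smaller maximal response, a higher number a larger maximal response:
compound 1 `Cc1nc(S(C)(=O)=O)ccc1Oc1ncnc(OC2CCN(C(=O)OC(C)C)CC2)c1F` gives 77%
compound 2 `CCC1(OC(=O)N2CCC(Oc3ncnc(Oc4ccc(S(C)(=O)=O)nc4C)c3F)CC2)CC1` gives 83%
compound 3 `Cc1nc(S(C)(=O)=O)ccc1Oc1ncnc(OC2CCN(C(=O)SC3(C)CC3)CC2)c1F` gives 77%

Compound 2 stands highest of the three numbers, but compound 1 and compound 3 are each within the scatter of it, so no order is established. The three measured steps all sit on the same carbonyl carbon: a number 6 percentage points higher from compound 1 to compound 2 (within the scatter), no change at the digits printed from compound 1 to compound 3 (within the scatter) and a number 6 percentage points lower from compound 2 to compound 3 (within the scatter). None moves the maximal response beyond the scatter.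

Compound 4 `Cc1nc(S(C)(=O)=O)ccc1Oc1ncnc(OC2CCN(C(=O)c3nc(C(C)(C)F)no3)CC2)c1F` differs from compound 2 in the same place: a group of 9 heavy atoms (5 carbon, 2 nitrogen, 1 oxygen, 1 fluorine; one five-membered aromatic ring with 3 hetero atoms) in place of a group of 6 heavy atoms (5 carbon, 1 oxygen; one three-membered non-aromatic ring of carbon only), on a carbonyl carbon. For the measured compounds named here, this change is larger than any of the measured ones, and no measured step covers an aromatic group on that carbonyl carbon. Given that every step at this position so far stayed within the scatter, the step in this assay is expected to be a number 5 percentage points lower from compound 2 to compound 4 (within the scatter), with the range widened for the untested group. Compound 4 is therefore estimated at 78%, between 58% and 96%.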

Compound 4, largest response reached (reported as efficacy), in percent of the reference or control that the assay uses: 84%
For compound 4 the middle estimate is 6 percentage points below the measured one; measured number inside the range.
By their numbers in this assay, from the lowest: compounds 1, 3, 2 and 4 (each within the scatter of the next).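

The carbonyl carbon on the amide-type nitrogen in a ring now carries an aromatic group, the five-membered ring with 3 hetero atoms, and in this assay this larger group stays within the scatter of all three earlier groups (a number 1 percentage points higher from compound 2 to compound 4 (within the scatter); a number 7 percentage points higher from compound 3 to compound 4 (within the scatter); a number 7 percentage points higher from compound 1 to compound 4 (within the scatter)). Across the four compounds, no group at this position separates from the others in maximal response. No supporting measurement accompanies this result. Open, on these data alone, is whether a phenyl ring, a simple alkyl amine or a carboxylic acid at this carbonyl carbon would behave the same way.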